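The compounds below may be only part of what the source reports. "The series", "measured", "known", "first", "only" and "open" are said of these compounds alone.

Measured so far:
compound 1 `C=CC1=C(C(=O)NCc2ccccc2)C(c2ccc(Cl)c(Cl)c2)OC1` — > 100000 nM
compound 2 `C=CC1=C(C(=O)NCCCCC)C(c2ccc(F)cc2)OC1` — > 100000 nM
compound 3 `C=CC1=C(C(=O)NCc2ccccc2)C(c2ccc(OC)cc2)OC1` — > 100000 nM

Each of these three values is a limit of the assay, not a number. Compound 1 therefore stands only at the limit of a functional assay on A549 cells (Homo sapiens) for cytotoxicity, read by MTT assay, with a stated time of 24 h (a higher number here means a weaker inhibitor, a lower number a stronger inhibitor), the position that the limit of > 100000 nM in this assay, at which 3 of the 3 values shown sit, describes; compounds 2 and 3 stand at the same limit, so no ordering among the three can be read.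

Compound 4 `C=CC1=C(C(=O)NCC(C)C)C(c2ccc(Cl)c(Cl)c2)OC1` differs from compound 1 by isopropyl in place of phenyl on a saturated chain carbon bound to an amide-type nitrogen. Within the data shown here, the only measured step touching compound 1 is a step that the two limits leave unreadable from compound 1 to compound 3, which concerns the aryl group on the saturated ring carbon rather than the amide side, and its size cannot be read. Among the measured compounds shown here, no measured step bears on the benzyl to isobutyl exchange. Compound 4 is therefore expected to remain at the limit, with an estimate of 150000 nM and a range of 60000 nM to 400000 nM. The expected step is a step that the limit leaves unreadable from compound 1 to compound 4, which is no change beyond the scatter.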

Compound 4, half-maximal inhibitory concentration: > 100000 nM
Compound 4 was reported as a limit; the forecaster's own chance of this, stated with the estimate: 85%; the middle value lies beyond the limit too.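

The step from compound 1 to compound 4 cannot be read: both values are limits, not numbers. The compounds shown leave open whether any change on the amide side or the aryl group gives a measurable value in this assay.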